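From a Fluorinated Ring to a Small Carbocycle

The source may report more compounds than this note shows. Statements on the series, on what has been measured and on what is new or still open speak of the compounds shown alone.

Of the compounds shown here, two have been tested in an in vitro functional assay on cells for agonist activity at Bombesin receptor subtype-3 (Homo sapiens), read by luminescence and calcium flux; on this read-out higher numbers stand for an effect only at larger amounts of compound and lower numbers for an effect already at smaller amounts. Compound 1 `CCCCc1cnc(CCCc2ccc(-c3ccccc3C(=O)O)cc2)[nH]1` gives 5600 nM, whereas compound 2 `O=C(O)c1ccccc1-c1ccc(CCc2ncc(Cc3ccccc3F)[nH]2)cc1` gives 177 nM, the lowest of the two numbers and separated from compound 1 by a gap beyond the usual scatter. Compound 3 `O=C(O)c1ccccc1-c1ccc(CCc2ncc(CC3CC3)[nH]2)cc1` awaits measurement; it differs from compound 2 by cyclopropyl in place of 2-fluorophenyl on a saturated chain carbon bound to an aromatic carbon. For the measured compounds named here, no pair of measured compounds differing in one place is available, so the expectation rests on compound 2 alone. A moderate shift toward a higher number is expected, an 8.5-fold higher number from compound 2 to compound 3 (0.93 log units; beyond the scatter). Compound 3 is estimated at 1500 nM, with a range from 300 nM to 8000 nM.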

Compound 3, half-maximal effective concentration: 1000 nM
Compound 3: the middle estimate sits 1.5-fold (0.18 log units) above what was measured; low and high end bracket the measured number.
By their numbers in this assay, from the lowest: compound 2; then compound 3; then compound 1.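

In this assay, putting cyclopropyl in place of 2-fluorophenyl on this saturated chain carbon gives a 5.6-fold higher number from compound 2 to compound 3 (0.75 log units; beyond the scatter) and so shows that the number responds to the group held at this place. The change removes the fluorine and the six-membered aromatic ring together, replacing them with a three-membered non-aromatic ring of carbon only. Nothing available explains the shift. As far as these compounds go, the shares of the fluorine and the ring size remain open. Plain benzyl or cyclohexylmethyl at the same place would begin to separate them.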